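Defluorination at the aminophenyl amide in a benzylamine series

The source may report more compounds than this note shows. Statements on the series, on what has been measured and on what is new or still open speak of the compounds shown alone.

Measured compounds
compound 1: `CN(C)c1ccc(C(=O)N(CC(=O)NCc2ccccc2)Cc2ccc(C(=O)Nc3cc(-c4ccccc4)ccc3N)cc2)cc1` – > 10000 nM
compound 2: `CN(C)c1ccc(C(=O)N(CCCCCC(=O)Nc2cc(F)ccc2N)CC(=O)NCc2ccccc2)cc1` – > 10000 nM

Compound 1, `CN(C)c1ccc(C(=O)N(CC(=O)NCc2ccccc2)Cc2ccc(C(=O)Nc3cc(-c4ccccc4)ccc3N)cc2)cc1`, gives in an assay on Sf9 cells for inhibition of protein deacetylase HDAC6 (Homo sapiens), read by fluorescence, with a stated time of 90 min (a lower number here means a stronger inhibitor, a higher number a weaker inhibitor), a value of > 10000 nM, which is a limit of the assay and not a number. Compound 2, `CN(C)c1ccc(C(=O)N(CCCCCC(=O)Nc2cc(F)ccc2N)CC(=O)NCc2ccccc2)cc1`, gives in this assay a value of > 10000 nM, again a limit rather than a number. Among the measured compounds shown here, compound 2 therefore stands only at a limit, and the one further value shown is also a limit: both sit at the limit of > 10000 nM in this assay, at which 2 of the 2 values shown sit, so no measured step can be drawn between them.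

Compound 3, `CN(C)c1ccc(C(=O)N(CCCCCC(=O)Nc2ccccc2N)CC(=O)NCc2ccccc2)cc1`, is the next member. It differs from compound 2 by hydrogen in place of fluoro on an aromatic carbon, on a six-membered aromatic ring of carbon only, meta to a large group and para to an amino group. For the measured compounds named here, no step between measured compounds is available as a guide. The expected step from compound 2 to compound 3 in this assay is a step that the limit leaves unreadable from compound 2 to compound 3, with no direction beyond the usual scatter anticipated. Compound 3 is accordingly estimated at 15000 nM, with a range from 4000 nM to 60000 nM, most likely reported again as a limit.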

Compound 3, half-maximal inhibitory concentration: > 10000 nM
Compound 3: no number, only a limit; the forecaster's own chance of this, stated with the estimate: 80%; the middle value does not contradict the limit.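

In this assay compound 3 gives > 10000 nM, a limit of the assay and not a number. Compound 2 also stands only at a limit, so no step can be read from compound 2 to compound 3: the limit of > 10000 nM in this assay, at which 3 of the 3 values shown sit.

The compounds shown leave open how hydrogen in place of fluoro affects inhibition once a value can be read as a number.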